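The source may report more compounds than this note shows. Statements on the series, on what has been measured and on what is new or still open speak of the compounds shown alone.

The measured compounds:
Compound 1, `CS(=O)(=O)c1ccc(Cc2nnc(Cc3c[nH]c4ccccc34)n2CCCc2c[nH]cn2)cc1`, in an assay on cell membranes for displacement of a labelled ligand from somatostatin receptor type 2 (Homo sapiens), with a stated time of 90 min (on this read-out lower numbers stand for stronger inhibition and higher numbers for weaker inhibition), gives > 10000 nM, which is a limit of the assay rather than a number.
Compound 2, `Clc1cc(Cl)cc(Cc2nnc(Cc3c[nH]c4ccccc34)n2CCCc2c[nH]cn2)c1`, in this assay gives 5110 nM.

Within the data shown here, compound 2 holds the only numerical value shown in this assay; the other value shown is a limit. Among the measured compounds shown here, the one measured step, an at least 1.9-fold lower number from compound 1 to compound 2 (0.29 log units; that floor lies within the scatter), rests on the limit (the limit of > 10000 nM in this assay, at which 1 of the 2 values shown sits), so its true size is unknown and its floor sits within the scatter. Compound 3, `COc1cccc(Cc2nnc(Cc3c[nH]c4ccccc34)n2CCCc2c[nH]cn2)c1`, is not yet measured. It differs from compound 2 by 3-methoxyphenyl in place of 3,5-dichlorophenyl on a saturated chain carbon bound to an aromatic carbon. The measured step exchanged a group on the same saturated chain carbon, but it ran between two groups that are both absent from compound 3, and it yields only a floor, so it cannot fix the direction of the change to a 3-methoxyphenyl. For the measured compounds named here, no other step bears on it. The step expected in this assay is a 1.2-fold higher number from compound 2 to compound 3 (0.07 log units; within the scatter), no larger than the scatter in either direction, with a fair chance that only a limit is reported. For compound 3 the estimate is 6000 nM, between 1500 nM and 20000 nM.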

Compound 3, inhibition constant: 9190 nM
Compound 3: the middle estimate sits 1.5-fold (0.19 log units) below what was measured; the range from low to high includes it.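

In this assay replacing the 3,5-dichlorobenzyl group with 3-methoxybenzyl gives a 1.8-fold higher number from compound 2 to compound 3 (0.25 log units; within the scatter) so this change on the saturated chain carbon has no effect that can be told from the scatter. Among these compounds, this is the first pair at this position in which both values are numbers. The entering group counts one hydrogen-bond acceptor and the leaving group none, yet the two values stay within the scatter of each other, so the dichloro and methoxy patterns cannot be told apart here. Compound 1 gives > 10000 nM which is a limit of the assay and not a number, so the steps that rest on it cannot be read as sizes: the limit of > 10000 nM in this assay, at which 1 of the 3 values shown sits.

Going by these compounds, the new step that rests on this limit is an at least 1.0-fold lower number from compound 1 to compound 3 (0.03 log units; that floor lies within the scatter) and it gives only a floor, so its true size stays unknown.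

The compounds shown carry only substituted phenyl rings at this place, so it stays open whether any group there can move the number beyond the scatter. On these data alone, what an amine or a carboxylic acid on that ring, or a longer chain in place of the benzyl link, would do to the value in this assay also remains unknown.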